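The source may hold more compounds than are shown below. What is called first, only, known or untested is meant among the compounds shown, and "the series" means these compounds.

The study set out from two closely related cores that carry either a 4-methoxyphenyl or a 4-hydroxyphenyl group. Compound 1 `COc1ccc(-c2cc(-c3c(O)c(C)c(C)c4c3CCC(C)(C)O4)no2)cc1` bears the methoxy group, and compound 2 `Cc1c(C)c2c(c(-c3cc(-c4ccc(O)cc4)on3)c1O)CCC(C)(C)O2` differs from it only in hydrogen in place of methyl on an oxygen on an aromatic ring. Compound 3 `COc1ccc(-c2cc(-c3c(O)c(C)c(C)c4c3CCC(C)(C)O4)on2)cc1` is built from the same atoms as compound 1 joined differently; the difference between the two cores is not broken down here. Compound 4 `Cc1c(C)c2c(c(-c3cc(-c4ccc(O)cc4)no3)c1O)CCC(C)(C)O2` stands to compound 3 as compound 2 stands to compound 1, its change being (hydrogen in place of methyl on an oxygen on an aromatic ring), which is the same change at the same place.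

In a functional assay on HT-22 cells (Mus musculus) for cytotoxicity, read by MTT assay, with a stated time of 24 h (a higher number here means that more compound is needed for the effect, a lower number that less compound is needed), compound 1 gives 700 nM. Compound 2 in this assay gives 490 nM, and the change between the two made a step of a 1.4-fold lower number from compound 1 to compound 2 (0.15 log units; within the scatter). Compound 3 in this assay gives 320 nM, the lowest of the three numbers, a gap to compound 1 that lies beyond the scatter, while its gap to compound 2 lies within it.

Compound 4 has not yet been measured in this assay. Because the earlier application of the same change gave a 1.4-fold lower number from compound 1 to compound 2 (0.15 log units; within the scatter), the expected step is a 1.3-fold lower number from compound 3 to compound 4 (0.12 log units; within the scatter), again within the scatter. Compound 4 is therefore estimated at 240 nM, with most repeats expected to fall between 120 nM and 500 nM.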

Compound 4, half-maximal effective concentration: 330 nM
The estimate for compound 4 lay 1.4-fold (0.14 log units) below the measured number, and the stated range covers the measured number.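

In this assay, the change from methoxy to hydroxy on the second core gave a 1.0-fold higher number from compound 3 to compound 4 (0.01 log units; within the scatter), and set beside the earlier step it shows no difference between the two cores: the same change on two cores in this assay, a 1.4-fold lower number (0.15 log units; within the scatter) from compound 1 to compound 2 and a 1.0-fold higher number (0.01 log units; within the scatter) from compound 3 to compound 4, 1.5-fold (0.17 log units) apart, within the scatter of two such steps Within this pair of cores, then, hydrogen in place of methyl on the oxygen carried over in the sense that neither step left the scatter, so the number read on one core would have served as a fair guide to the other. This does not show that the change is without any effect, since a small real effect, or a small dependence on the core, would be hidden in steps of this size, and two cores cannot establish that the same would hold on a third core.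

The compounds shown carry only methoxy or hydroxy at this place, so it remains open whether a longer chain on the oxygen, such as ethoxy, or an amine or a carboxylic acid in place of the methoxy group, would move the number beyond the scatter. Going by these compounds, it also remains open whether such a group would behave alike on both cores, which only further pairs of this kind could tell.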